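The source may hold more compounds than are shown below. What is called first, only, known or untested is meant among the compounds shown, and "the series" means these compounds.

Measured so far: compound 1 `C=CC(=O)Nc1ccc(Cn2nc(-c3ccc(Oc4ccccc4)cc3)cc2C(=O)O)cc1` with > 60000 nM; compound 2 `C=CC(=O)Nc1ccc(Cn2nc(-c3ccc(Oc4ccccc4)cc3)cc2CO)cc1` with 6800 nM.

In a functional assay on Z-138 cells (Homo sapiens) for inhibition, read by luminescence and CellTiter-Glo, with a stated time of 72 h (on this read-out higher numbers stand for weaker inhibition and lower numbers for stronger inhibition), compound 1 gives > 60000 nM, which is a limit of the assay and not a number, as the limit of > 60000 nM in this assay, at which 1 of the 2 values shown sits, records. Compound 2 gives 6800 nM in this assay. For the measured compounds named here, the only measured step, an at least 8.8-fold lower number from compound 1 to compound 2 (0.94 log units; beyond the scatter), alters the carboxy group on the shared core and says nothing about the ring that is changed on the way to compound 3. Compound 3 `C=CC(=O)Nc1cccc(Cn2nc(-c3ccc(Oc4ccccc4)cc3)cc2C(=O)O)c1` keeps the carboxy group of compound 1 and differs from it by 3-((vinylcarbonyl)amino)phenyl in place of 4-((vinylcarbonyl)amino)phenyl on a saturated chain carbon bound to an aromatic nitrogen. Going by the values given here, no measured pair shows such a rearrangement, so the direction and size of the step rest only on where compound 1 stands, which is at the limit. With the carboxy group retained, compound 3 is expected to stay weak in this assay, with an estimated value of about 60000 nM between 15000 nM and 120000 nM, and quite possibly again reported only as a limit. The step that this estimate implies, a number no higher from compound 1 to compound 3 (the limit leaves the size open), is expected to be no more than a nominal one.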

Compound 3, half-maximal inhibitory concentration: 28500 nM
Compound 3: middle estimate off by 2.1-fold (0.32 log units), on the high side; the range from low to high includes it.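

With the carboxy group kept, the change to 3-((vinylcarbonyl)amino)phenyl in place of 4-((vinylcarbonyl)amino)phenyl on a saturated chain carbon bound to an aromatic nitrogen gives, in this assay, an at least 2.1-fold lower number from compound 1 to compound 3 (0.32 log units; beyond the scatter). For the compounds shown here, the earlier step, an at least 8.8-fold lower number from compound 1 to compound 2 (0.94 log units; beyond the scatter), involved only the carboxy group, so this is the first sign that the group on the saturated chain carbon also bears on the read-out. The value of compound 1 is a limit of the assay and not a number, which leaves the true size of the new step open at one end: the limit of > 60000 nM in this assay, at which 1 of the 3 values shown sits.

It remains open whether hydroxymethyl in place of carboxy would also give a lower number when combined with 3-((vinylcarbonyl)amino)phenyl, as the two changes are shown only separately. Also open, from the compounds shown here alone, is how the read-out would respond to a methyl ester or a primary amide in place of the carboxy group, or to a propanoyl amide in place of the vinylcarbonyl amide on the 3-substituted phenyl group.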